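Swapping a Methylpyrrole for Isobutyl: a Stability Outlook

The compounds below may be only part of what the source reports. "The series", "measured", "known", "first", "only" and "open" are said of these compounds alone.

Measured so far:
compound 1, `CC(C)CCn1nc(-c2cccs2)c(O)c(C2=NS(=O)(=O)c3cc(NS(=O)(=O)C4CC4)ccc3N2)c1=O`
compound 2, `CC(C)CCn1nc(-c2ccn(C)c2)c(O)c(C2=NS(=O)(=O)c3cc(NS(C)(=O)=O)ccc3N2)c1=O`

Of the compounds shown here, two have been measured in an in vitro ADME assay on microsomes from liver (Homo sapiens) for metabolic stability, tested at 5 uM; a higher number here means that the compound lasts longer, a lower number that the compound disappears faster. For compound 1 the result is reported only as a limit of the assay, > 1 h. Compound 2 gives 0.633 h. For the measured compounds named here, compound 2 therefore stands on the only number given, while the other result is a limit, as recorded in the limit of > 1 h in this assay, at which 1 of the 2 values shown sits.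

Compound 3, `CC(C)CCn1nc(CC(C)C)c(O)c(C2=NS(=O)(=O)c3cc(NS(C)(=O)=O)ccc3N2)c1=O`, has not yet been measured. It differs from compound 2 in a single place: isobutyl in place of 1-methyl-1H-pyrrol-3-yl on an aromatic carbon. Going by the values given here, no step between two measured compounds is available here, so nothing in the data shows how large a change of this kind produces in this assay, or in which direction.

The step is estimated as a 1.0-fold higher number from compound 2 to compound 3 (0.01 log units; within the scatter), which is expected to stay within the usual scatter rather than move the half-life clearly up or down. Compound 3 is expected to give about 0.65 h in this assay, with a plausible range from 0.32 h to 1.3 h. The chance that the assay returns only a limit for compound 3 cannot be ruled out.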

Compound 3, half-life: 0.123 h
The estimate for compound 3 lay 5.3-fold (0.72 log units) above the measured number; measured number below the stated range.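

For the compounds shown here, this is the first single change measured at this position, an aromatic carbon next to the ring nitrogen and ortho to a hydroxy group, and it shows that in this assay the group placed there is not indifferent. Isobutyl in place of 1-methyl-1H-pyrrol-3-yl gives a 5.1-fold lower number from compound 2 to compound 3 (0.71 log units; beyond the scatter) and this lies beyond the scatter, so of these two groups the open chain, with no ring and no hydrogen-bond acceptor, goes with the shorter half-life. Compound 1 could not show this, as it differs from compound 2 in more than one place and its result is only a limit of the assay.

Nothing measured here bears on the reason for this step. As far as these compounds go, with one step at one position, it remains open whether a cyclopropyl group, a phenyl ring, a morpholine or a longer alkyl chain at this carbon would follow isobutyl or 1-methyl-1H-pyrrol-3-yl, and whether the same change would have a step of similar size alongside the cyclopropyl sulfonamide of compound 1.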